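A few compounds are considered here, and "the series" means these few. Any claim that something is new, unique, unknown or untested is made for them only; others in the source may bear on it.

Going by the values given here, in a functional assay (Nicotiana tabacum) (a lower number here means a stronger inhibitor, a higher number a weaker inhibitor), only two compounds with the shared core have numbers so far. Compound 1 (`CSc1nc(NC2CCC2)c2cccnc2n1`) carries a cyclobutyl on a nitrogen and reads 720 nM as its half-maximal inhibitory concentration. Compound 2 (`CSc1nc(Nc2ccccc2)c2cccnc2n1`) carries a phenyl there and stands highest of the two (15900 nM), which makes it the weaker inhibitor. Among the compounds with values here, the one measured step (a 22-fold higher number from compound 1 to compound 2 (1.34 log units; beyond the scatter)) is large and beyond the scatter. Compound 3 (`CSc1nc(Nc2ccc(Cl)cc2)c2cccnc2n1`) keeps that phenyl and adds one change (chloro in place of hydrogen on an aromatic carbon), namely chloro in place of hydrogen on an aromatic carbon, para to a large group. Within the data shown here, no measured step involves a chloro. The step from cyclobutyl to phenyl (a 22-fold higher number from compound 1 to compound 2 (1.34 log units; beyond the scatter)) bears on this only loosely. It shows that the group on that nitrogen can move the number in this assay a lot, but it swapped the whole group, while here the phenyl stays. A far smaller step is therefore expected, perhaps towards a slightly lower number and possibly no larger than the scatter. The estimate is a small step (a 1.6-fold lower number from compound 2 to compound 3 (0.20 log units; within the scatter)). For compound 3 the estimated value is about 10000 nM (expected range 3000 nM to 35000 nM).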

Compound 3, half-maximal inhibitory concentration: 8510 nM
Beside the measured number, compound 3's estimate is 1.2-fold (0.07 log units) above it; the range from low to high includes it.
By their numbers in this assay, from the lowest: compound 1; then compounds 3 and 2 (each within the scatter of the next).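

In this assay there is a 1.9-fold lower number from compound 2 to compound 3 (0.27 log units; within the scatter) for the first change made on the phenyl itself, so adding a chloro on an aromatic carbon, para to a large group, cannot be told apart from keeping hydrogen there. The earlier step replaced the whole group on the nitrogen, whereas this one shows that, with the phenyl kept, adding this one heavy atom at this place stays within the normal variation between repeated measurements. No supporting measurement bears on why the number behaves this way.

As far as these compounds go, it remains open whether a different group at the same place, such as an amine, a methoxy or a carboxylic acid, would give a step beyond the scatter, and whether a chloro elsewhere on that ring would read the same as compound 3. It is also unknown whether any group on the phenyl could bring the number close to that of compound 1 at 720 nM in this assay or whether that level needs the cyclobutyl.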